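This account rests on a few compounds, and the source may have more. Where it says the series, first, only, none or still open, it means among the compounds named here.

In an ADME assay on HEK293 cells (Homo sapiens) for cytotoxicity, read by MTT assay, with a stated time of 24 h (a higher number here means a weaker inhibitor, a lower number a stronger inhibitor), three compounds that share one core have been measured. Compound 1 `CN(C)CCCNc1nc2cc([N+](=O)[O-])ccc2nc1NCc1ccccc1`, which has no substituent on its benzyl ring, gives 2.74 ug/mL. Compound 2 `CN(C)CCCNc1nc2cc([N+](=O)[O-])ccc2nc1NCc1ccccc1C(F)(F)F` gives 24.7 ug/mL, and compound 3 `CN(C)CCCNc1nc2cc([N+](=O)[O-])ccc2nc1NCc1ccccc1Br` gives 51.9 ug/mL, the highest number of the three. Compound 4 `Cc1ccccc1CNc1nc2ccc([N+](=O)[O-])cc2nc1NCCCN(C)C` has not yet been measured. It differs from compound 3 by methyl in place of bromo on an aromatic carbon, with methyl in place of bromo on an aromatic carbon, so that 2-bromobenzyl becomes 2-methylbenzyl.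

Among the measured compounds shown here, three measured steps bear on this change. Replacing hydrogen on the aromatic carbon gave a 9.0-fold higher number from compound 1 to compound 2 (0.95 log units; beyond the scatter) with trifluoromethyl and a 19-fold higher number from compound 1 to compound 3 (1.28 log units; beyond the scatter) with bromo. Exchanging one of those groups for the other moved the number far less, giving a 2.1-fold higher number from compound 2 to compound 3 (0.32 log units; beyond the scatter), a modest step that is still beyond the scatter. For the measured compounds named here, no measured compound carries methyl, so the comparison rests on these three compounds alone. Exchanging bromo for methyl is therefore expected to be a similarly modest step towards a lower number, not a full return to the level of compound 1 at 2.74 ug/mL. The estimated change is a 2.6-fold lower number from compound 3 to compound 4 (0.41 log units; beyond the scatter). Compound 4 is accordingly expected at 20 ug/mL, with an estimated range of 6 ug/mL to 60 ug/mL.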

Compound 4, half-maximal inhibitory concentration: 27.6 ug/mL
Compound 4: middle estimate off by 1.4-fold (0.14 log units), on the low side; the measured number falls inside the stated range.
By their numbers in this assay, from the lowest: compound 1; then compounds 2, 4 and 3 (each within the scatter of the next, the first and the last beyond it).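

With methyl on the benzyl ring, the number stands at a 10-fold higher number from compound 1 to compound 4 (1.00 log units; beyond the scatter), so trifluoromethyl, bromo and methyl at this position all lie beyond the scatter from the unsubstituted compound 1 in this assay and all in the same direction. Exchanging bromo for methyl gives a 1.9-fold lower number from compound 3 to compound 4 (0.27 log units; within the scatter) and exchanging trifluoromethyl for methyl gives a 1.1-fold higher number from compound 2 to compound 4 (0.05 log units; within the scatter), so among these three substituted compounds the exchange of one group for another moves the number far less than replacing hydrogen does, although a 2.1-fold higher number from compound 2 to compound 3 (0.32 log units; beyond the scatter) is a pair that goes against a complete levelling by lying just beyond the scatter. No measurement offered here explains why replacing hydrogen at this position moves the number while exchanging these groups barely does.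

The compounds shown leave open whether a group of another kind on this carbon, such as a hydroxyl, an amine or a carboxylic acid, would move the number as far from compound 1 as these three groups do. They also leave open whether methyl or bromo would give a similar number on another carbon of the benzyl ring, or with a longer chain in place of the dimethylaminopropyl chain.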